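The source may hold more compounds than are shown below. What is called first, only, known or untested is meant among the compounds shown, and "the series" means these compounds.

Compound 1 `COc1ccc(C(=O)Nc2cc(Cl)ccc2OCC(=O)Nc2ccc(S(N)(=O)=O)cc2C)cc1`: 69500 nM
Compound 2 `Cc1cc(S(N)(=O)=O)ccc1NC(=O)COc1ccc(Cl)cc1NC(=O)c1cc(Cl)cc(Cl)c1`: 72400 nM

In a functional assay on C8166 cells (Homo sapiens) for cytotoxicity, read by MTT assay (on this read-out higher numbers stand for lower toxicity in this test and lower numbers for higher toxicity in this test), compound 2 gives 72400 nM, which is level with compound 1 within the scatter. Compound 3 `Cc1cc(S(N)(=O)=O)ccc1NC(=O)COc1ccc(Cl)cc1NC(=O)c1ccc2ccccc2c1` has naphthalen-2-yl in place of 3,5-dichlorophenyl on a carbonyl carbon. Within the data shown here, only one measured step changes the group at this place, a 1.0-fold higher number from compound 1 to compound 2 (0.02 log units; within the scatter). With so small a precedent, no step beyond the scatter is expected in this assay, although a single step is thin evidence. The expected change is a 1.2-fold lower number from compound 2 to compound 3 (0.07 log units; within the scatter). For compound 3 the estimated value is 62000 nM, with an expected range of 27000 nM to 130000 nM.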

Compound 3, half-maximal cytotoxic concentration: 37600 nM
Compound 3: the middle estimate sits 1.6-fold (0.22 log units) above what was measured; the measured number falls inside the stated range.
By their numbers in this assay, from the lowest: compounds 3, 1 and 2 (each within the scatter of the next).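

Naphthalen-2-yl on the carbonyl carbon gives a 1.9-fold lower number from compound 2 to compound 3 (0.28 log units; within the scatter) and a 1.8-fold lower number from compound 1 to compound 3 (0.27 log units; within the scatter) in this assay on the shared core. Among these compounds, a group with two six-membered aromatic rings of carbon only and no chlorine thus stays level with both 3,5-dichlorophenyl and 4-methoxyphenyl, which the single earlier step could not show. Across these three compounds, no change at this place goes beyond the scatter.

Going by these compounds, whether a cyclohexyl group, or a phenyl ring carrying an amine or a carboxylic acid, would stay as level at this carbonyl carbon remains open. Nothing given here explains why these numbers sit so close.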